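The source may report more compounds than this note shows. Statements on the series, on what has been measured and on what is new or still open speak of the compounds shown alone.

Compound 1 `O=C(/C=C/c1ccc(OCCCCO[N+](=O)[O-])c(O)c1)OCCCCO[N+](=O)[O-]` and compound 2 `O=C(/C=C/c1ccc(O)c(O)c1)OCc1c(-c2ccccc2)no[n+]1[O-]` share a cinnamate ester framework but carry different cores; the difference between the two cores is not broken down here. In a functional assay on NCI-H460 cells (Homo sapiens) for cytotoxicity, read by resazurin assay, with a stated time of 72 h (a higher number here means a weaker inhibitor, a lower number a stronger inhibitor), compound 1 reaches only the limit of the assay, > 50000 nM, and no number is known for it. Compound 2, by contrast, gives 2540 nM in this assay. Compound 3 `COc1cc(/C=C/C(=O)OCc2c(-c3ccccc3)no[n+]2[O-])ccc1O` carries the change methyl in place of hydrogen on an oxygen on an aromatic ring relative to compound 2, and in this assay compound 3 gives 7030 nM, so that the step of a 2.8-fold higher number from compound 2 to compound 3 (0.44 log units; beyond the scatter) is a modest loss of potency. The same change, (methyl in place of hydrogen on an oxygen on an aromatic ring), turns compound 1 into compound 4 `COc1cc(/C=C/C(=O)OCCCCO[N+](=O)[O-])ccc1OCCCCO[N+](=O)[O-]`, which has not yet been measured in this assay. Because compound 1 already sits at the limit of > 50000 nM in this assay, at which 1 of the 3 values shown sits, and because the measured step of a 2.8-fold higher number from compound 2 to compound 3 (0.44 log units; beyond the scatter) moved the number upward rather than downward, compound 4 is expected to remain beyond the reach of the assay. The estimated step that the limit leaves unreadable from compound 1 to compound 4 is therefore expected to be small or unresolvable, and compound 4 is expected to give about 120000 nM in this assay, somewhere between 40000 nM and 400000 nM.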

Compound 4, half-maximal inhibitory concentration: > 50000 nM
Compound 4 gave a limit, no number; the forecaster's own chance of this, stated with the estimate: 85%; the middle value is on the limit's open side.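

Compound 1 and compound 4 both end at a limit rather than a number, so no new step can be read between them: the limit of > 50000 nM in this assay, at which 2 of the 4 values shown sit.

The compounds shown leave open how far beyond that limit compound 1 and compound 4 lie, and so whether hydroxy to methoxy changes anything on the core of compound 1.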